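The source may hold more compounds than are shown below. What is called first, only, known or untested is meant among the compounds shown, and "the series" means these compounds.

In an ADME assay on liver for metabolic stability, with Liver microsome (Homo sapiens) as the target, using microsomes (a lower number here means slower removal, a higher number faster removal of the compound), compound 1 (`COc1ccc(C(=O)Nc2[nH]nc(-c3ccccn3)c2C2CC2)cc1`) gives 12.8 mL.min-1.g-1, and compound 2 (`O=C(Nc1cc(-c2ccccn2)n[nH]1)N1CCC(c2ccc(F)cc2)CC1`) gives 42.5 mL.min-1.g-1, the higher of the two numbers and beyond the scatter of compound 1. Compound 3 (`O=C(Nc1cc(-c2ccccn2)n[nH]1)N1CCC(c2cccc(Cl)c2)CC1`) has 3-chlorophenyl in place of 4-fluorophenyl on a saturated ring carbon. Among the measured compounds shown here, no measured pair differs in one place only, so nothing yet shows what this swap does in this assay. The expected step is a 1.1-fold higher number from compound 2 to compound 3 (0.05 log units; within the scatter), slightly upward but not beyond the scatter. For compound 3 the estimated value is 48 mL.min-1.g-1, with an expected range of 24 mL.min-1.g-1 to 95 mL.min-1.g-1.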

Compound 3, intrinsic clearance in microsomes: 30.8 mL.min-1.g-1
The estimate for compound 3 lay 1.6-fold (0.19 log units) above the measured number; the range from low to high includes it.
By their numbers in this assay, from the lowest: compound 1; then compounds 3 and 2 (each within the scatter of the next).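

In this assay, among the compounds shown here, the change to 3-chlorophenyl from 4-fluorophenyl on a saturated ring carbon gives a 1.4-fold lower number from compound 2 to compound 3 (0.14 log units; within the scatter) and is the only comparison here between compounds that differ in one place. At this position, these two substituted phenyl groups cannot be told apart in this read-out. No available evidence bears on this result. From the compounds shown here alone, it remains open whether an amine or a carboxylic acid at this position would move the number beyond the scatter. Also open, going by these compounds, is whether 3-chlorophenyl and 4-fluorophenyl would remain indistinguishable on the core of compound 1.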